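Methyl in place of hydrogen on the pyrazole-side phenyl

The source may report more compounds than this note shows. Statements on the series, on what has been measured and on what is new or still open speak of the compounds shown alone.

Among the measured compounds shown here, compound 2 `O=c1cc(-c2ccccc2)[nH]c2cc(-c3ccccc3)nn12` is the weaker of the two measured members: in a functional assay on U-251 cells (Homo sapiens) for cytotoxicity, read by resazurin assay, with a stated time of 48 h (on this read-out lower numbers stand for stronger inhibition and higher numbers for weaker inhibition), compound 2 gives 77700 nM, the highest of the two numbers, whereas compound 1 `COc1ccc(-c2cc(=O)n3nc(-c4ccccc4)cc3[nH]2)cc1` gives 13400 nM. For the measured compounds named here, the only measured step is a 5.8-fold higher number from compound 1 to compound 2 (0.76 log units; beyond the scatter), hydrogen in place of methoxy on an aromatic carbon.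

Compound 3 `Cc1ccc(-c2cc3[nH]c(-c4ccccc4)cc(=O)n3n2)cc1` is not yet measured. It differs from compound 2 by methyl in place of hydrogen on an aromatic carbon; the same difference, cut one bond further out, reads phenyl to 4-methylphenyl. Going by the values given here, the step from compound 1 to compound 2 bears on it only loosely: it concerns a methoxy rather than a methyl, and the group sits on a different phenyl of the shared core, so no measured pair shows what a methyl on this phenyl does. Given that one measured substituent on a phenyl lowered the number, a small drop is expected, within or just beyond the scatter, as a 1.7-fold lower number from compound 2 to compound 3 (0.24 log units; within the scatter). For compound 3 the expected value in this assay is therefore 45000 nM, with a range of 15000 nM to 130000 nM.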

Compound 3, half-maximal inhibitory concentration: 148000 nM
Estimate against measurement, compound 3: 3.3-fold (0.52 log units) below; measured number above the stated range.
By their numbers in this assay, from the lowest: compound 1; then compounds 2 and 3 (each within the scatter of the next).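

Methyl in place of hydrogen, para to a large group on the pyrazole-side phenyl, gives the first reading at this position: in this assay the step is a 1.9-fold higher number from compound 2 to compound 3 (0.28 log units; within the scatter), so compound 3 cannot be told apart from compound 2 and this small group leaves the number within the usual scatter. Among the compounds shown here, the only step beyond the scatter remains a 5.8-fold higher number from compound 1 to compound 2 (0.76 log units; beyond the scatter), which concerns a methoxy on the other phenyl of the shared core, so the two steps differ in both group and place and form no rule for substituents on these phenyls. Nothing available explains the reading for the methyl at this position.

Going by these compounds, whether a methoxy on this phenyl would match the step seen on the other phenyl remains open, as does the effect of a methyl on that other phenyl. Also open, on these data alone, is whether a larger or different group at this place, such as an amine, a carboxylic acid or a longer alkyl chain, would move the number beyond the scatter in this assay.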